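The source may report more compounds than this note shows. Statements on the series, on what has been measured and on what is new or still open speak of the compounds shown alone.

Measured so far in a functional assay on CEM-CCRF cells for antagonist activity at C-X-C chemokine receptor type 4 (Homo sapiens), read by calcium flux; a lower number here means a stronger inhibitor, a higher number a weaker inhibitor:
compound 1, `NCc1cccc(CN(Cc2nc3ccccc3[nH]2)C2CCCc3cccnc32)c1`, gives 1400 nM
compound 2, `NCC#CCN(Cc1nc2ccccc2[nH]1)C1CCCc2cccnc21`, gives 973 nM

Compound 2 holds the lowest of the two numbers in this assay, but its nearest neighbour is compound 1, and the step of a 1.4-fold lower number from compound 1 to compound 2 (0.16 log units; within the scatter) stays inside the scatter, so the two compounds cannot be told apart on these numbers. Compound 3, `CN(C)CCCCN(Cc1nc2ccccc2[nH]1)C1CCCc2cccnc21`, is the next compound, not yet measured in this assay. It differs from compound 2 in one place: 3-(dimethylamino)propyl in place of 3-aminoprop-1-yn-1-yl on a saturated chain carbon bound to an amine nitrogen. Within the data shown here, only one measured step exists, the one from compound 1 to compound 2, and it changed a different part of the same arm while keeping a single primary amine at its end; it produced no movement beyond the scatter. Among the measured compounds shown here, no measured step shows what happens when the alkyne becomes a saturated chain and the amine carries two methyl groups, so the expectation for compound 3 rests on the shared core and the tolerance seen so far. Compound 3 is therefore expected to land near compound 2, with a 1.2-fold higher number from compound 2 to compound 3 (0.09 log units; within the scatter) as the estimated step, and the estimate for compound 3 in this assay is 1200 nM, within a range from 400 nM to 3500 nM.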

Compound 3, half-maximal inhibitory concentration: 87 nM
For compound 3 the middle estimate is 14-fold (1.14 log units) above the measured one, outside the stated range (below it).
By their numbers in this assay, from the lowest: compound 3; then compounds 2 and 1 (each within the scatter of the next).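

In this assay the arm on a saturated chain carbon bound to an amine nitrogen proves able to move the number strongly, which the earlier pair did not show: 3-(dimethylamino)propyl in place of 3-aminoprop-1-yn-1-yl gives an 11-fold lower number from compound 2 to compound 3 (1.05 log units; beyond the scatter). Against the 3-(aminomethyl)phenyl arm the same group gives a 16-fold lower number from compound 1 to compound 3 (1.21 log units; beyond the scatter), so compound 3 stands clear of both earlier compounds, whose two arms could not be told apart in this assay. The change removes the triple bond and the hydrogen-bond donor of the arm together while adding two heavy atoms, and the compounds shown do not separate these differences, nor does any measurement here explain the drop.

The compounds shown leave open whether the gain follows the saturated chain or the dimethylamino end: a 3-aminopropyl arm, with its primary amine on the saturated chain, and a 3-(dimethylamino)prop-1-yn-1-yl arm, keeping the triple bond, would each divide the change. As far as these compounds go, how far the chain length matters also stays open, as a 4-(dimethylamino)butyl arm or a pyrrolidine at the chain end would show.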